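The compounds below may be only part of what the source reports. "The series", "measured", "known", "first", "only" and "open" are said of these compounds alone.

Of the compounds shown here, three sharing one core have been tested in an ADME assay on SW480 cells (Homo sapiens) for cytotoxicity, read by MTT assay, with a stated time of 72 h; on this read-out lower numbers stand for stronger inhibition and higher numbers for weaker inhibition. Compound 1 `O=C(NCC1CCCCC1)c1cccc(/C=C2\CC(=O)N(c3ccccc3)C2=O)c1` gives only a limit of the assay, > 100000 nM. Compound 2 `COc1ccc(NC(=O)c2cccc(/C=C3\CC(=O)N(c4ccccc4)C3=O)c2)c(C)c1` likewise gives only a limit, > 100000 nM. Compound 3 `O=C(Nc1ccc(Cl)cc1)c1cccc(/C=C2\CC(=O)N(c3ccccc3)C2=O)c1` also gives only a limit, > 100000 nM. Compound 3 therefore sits at the limit of > 100000 nM in this assay, at which 3 of the 3 values shown sit, with no ordering possible among the three. The change to compound 4 `O=C(c1cccc(/C=C2\CC(=O)N(c3ccccc3)C2=O)c1)N1CCCC1` is pyrrolidin-1-yl in place of (4-chlorophenyl)amino on a carbonyl carbon. Going by the values given here, the steps that bear on it, a step that the two limits leave unreadable from compound 1 to compound 2, a step that the two limits leave unreadable from compound 1 to compound 3 and a step that the two limits leave unreadable from compound 2 to compound 3, show no readable size, so no direction can be drawn from them. Given that every value so far sits at the limit of > 100000 nM in this assay, at which 3 of the 3 values shown sit, compound 4 is expected to read 150000 nM, within 40000 nM to 600000 nM. That estimate means an expected step that the limit leaves unreadable from compound 3 to compound 4.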

Compound 4, half-maximal inhibitory concentration: > 100000 nM
Compound 4: no number, only a limit; the forecaster's own chance of this, stated with the estimate: 75%; the middle value lies beyond the limit too.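

Compound 4, like compound 1, compound 2 and compound 3, gives only a limit, so no step among these four compounds can be read: the limit of > 100000 nM in this assay, at which 4 of the 4 values shown sit. The compounds shown leave open whether any of these groups on the carbonyl carbon makes a difference in this assay.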